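The source may report more compounds than this note shows. Statements on the series, on what has been measured and on what is new or still open speak of the compounds shown alone.

Measured in a functional assay on K562 cells (Homo sapiens), read by MTT assay, with a stated time of 72 h; on this read-out lower numbers stand for stronger inhibition and higher numbers for weaker inhibition:
- Compound 1 `CNc1ncnc2c1c(-c1cccs1)cn2[C@@H]1O[C@H](CO)[C@@H](O)[C@H]1O`: > 20000 nM
- Compound 2 `CNc1ncnc2c1c(-c1ccsc1)cn2[C@@H]1O[C@H](CO)[C@@H](O)[C@H]1O`: > 20000 nM

Compound 2 gives > 20000 nM, which is a limit of the assay and not a number. Both measured compounds stand at the limit of > 20000 nM in this assay, at which 2 of the 2 values shown sit, so compound 2 has no true number to build on.

Compound 3 `CN(C)c1ncnc2c1c(-c1ccsc1)cn2[C@@H]1O[C@H](CO)[C@@H](O)[C@H]1O` differs from compound 2 by one change: methyl in place of hydrogen on a nitrogen on an aromatic ring. In words, this is methyl in place of hydrogen on a nitrogen on an aromatic ring, or methylamino to dimethylamino.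

Among the measured compounds shown here, the only measured step is a step that the two limits leave unreadable from compound 1 to compound 2, where thiophen-3-yl replaces thiophen-2-yl on an aromatic carbon. It is a different change and offers no size to carry over. No step beyond the scatter is therefore expected in this assay, and no direction can be argued. The expected step is a number no higher from compound 2 to compound 3 (the limit leaves the size open). Compound 3 is estimated at 20000 nM, with an expected range from 8000 nM to 40000 nM, and it may well be reported only as a limit.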

Compound 3, half-maximal inhibitory concentration: 530 nM
For compound 3 the middle estimate is 38-fold (1.58 log units) above the measured one, and the stated range ends above it.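

In this assay, methyl in place of hydrogen on a nitrogen on an aromatic ring, which turns methylamino into dimethylamino, gives an at least 37-fold lower number from compound 2 to compound 3 (1.57 log units; beyond the scatter). Compound 2 gives > 20000 nM, which is a limit of the assay and not a number. This nitrogen is the first place among the compounds shown where a single change produces a readable shift, since the step between the two thiophene attachments cannot be read, and compound 3 alone has a true number: the limit of > 20000 nM in this assay, at which 2 of the 3 values shown sit.

On these data alone, what remains open is whether a longer chain on this nitrogen, as in diethylamino, or a ring amine such as pyrrolidin-1-yl would give a lower or a higher number. As far as these compounds go, it is also open whether dimethylamino would give a similar step alongside the thiophen-2-yl group of compound 1.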